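Sulfonyl to Carbonyl: A Step Beyond the Measured Pair

The compounds below may be only part of what the source reports. "The series", "measured", "known", "first", "only" and "open" are said of these compounds alone.

Of the compounds shown here, two have been measured. Compound 1 `COc1cc(N(Cc2nc3ccccc3[nH]2)S(=O)(=O)c2ccc(F)cc2)cc(OC)c1OC` gives 7990 nM in a functional assay on PC-3 cells (Homo sapiens) for inhibition, read by MTT assay, with a stated time of 48 h; on this read-out lower numbers stand for stronger inhibition and higher numbers for weaker inhibition. Compound 2 `COc1cc(N(Cc2nc3ccccc3[nH]2)S(=O)(=O)c2ccc(Br)cc2)cc(OC)c1OC` gives 6890 nM in this assay. The single measured step between them, a 1.2-fold lower number from compound 1 to compound 2 (0.06 log units; within the scatter), lies within the scatter, so on the numbers shown compound 2 stands level with compound 1 and neither can be set apart from the other.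

Compound 3 `COc1cc(N(Cc2nc3ccccc3[nH]2)C(=O)c2ccc(Br)cc2)cc(OC)c1OC` has not been measured. It differs from compound 2 in one place: (4-bromophenyl)carbonyl in place of (4-bromophenyl)sulfonyl on a nitrogen on an aromatic ring. For the measured compounds named here, no measured step bears on this change; the only step available concerns the halogen on the aromatic ring and says nothing about the link between the nitrogen and that ring. The data therefore give no direction for the change, and the expectation can only be anchored on compound 2 with a wide range around it. In this assay the expected step is a 1.0-fold higher number from compound 2 to compound 3 (0.01 log units; within the scatter), that is, no change beyond the scatter. The estimate for compound 3 is 7000 nM, with a range from 1500 nM to 30000 nM.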

Compound 3, half-maximal inhibitory concentration: 19900 nM
Estimate against measurement, compound 3: 2.8-fold (0.45 log units) below, within the range that was stated.
By their numbers in this assay, from the lowest: compounds 2 and 1 (each within the scatter of the next); then compound 3.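

For the compounds shown here, at this place, on a nitrogen on an aromatic ring, the link to the halogenated phenyl ring proves to count for more than the halogen itself did: in this assay, (4-bromophenyl)carbonyl in place of (4-bromophenyl)sulfonyl gives a 2.9-fold higher number from compound 2 to compound 3 (0.46 log units; beyond the scatter), a modest step but one beyond the scatter, while the only earlier step stayed within it. The fluoro compound points the same way, with (4-bromophenyl)carbonyl in place of (4-fluorophenyl)sulfonyl giving a 2.5-fold higher number from compound 1 to compound 3 (0.40 log units; beyond the scatter), so among these three compounds both sulfonyl compounds stand at lower numbers than the carbonyl compound, with none going against this. Nothing at hand accounts for the size or direction of this step.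

The compounds shown leave open whether the step from sulfonyl to carbonyl holds with a halogen other than bromo on the phenyl ring, or with a methoxy group or an amine in its place. They also leave open what a plain methylene link at the same nitrogen would give in this assay, and whether any change at this place can reach numbers well below those of compound 2.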